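The compounds below may be only part of what the source reports. "The series", "measured", "known", "first", "only" and "open" are said of these compounds alone.

In a functional assay on DU-145 cells (Homo sapiens) for inhibition, read by trypan blue exclusion, with a stated time of 96 h (on this read-out higher numbers stand for weaker inhibition of growth and lower numbers for stronger inhibition of growth), compound 1 `O=C(/C(=C\c1ccc(O)c([N+](=O)[O-])c1)SCc1ccc(Br)cc1)c1c(F)c(F)c(F)c(F)c1F` gives 10000 nM and compound 2 `O=C(O)c1ccc(C(=O)/C(=C\c2ccc(O)c([N+](=O)[O-])c2)SCc2ccc(Br)cc2)cc1` gives 50000 nM on the same core, with a different group on the carbonyl carbon. Compound 3 `N#Cc1ccc(C(=O)/C(=C\c2ccc(O)c([N+](=O)[O-])c2)SCc2ccc(Br)cc2)cc1` gives 10000 nM and stands level with compound 1, the two sharing the lowest of the three numbers. Compound 4 `O=C(/C(=C\c1ccc(O)c([N+](=O)[O-])c1)SCc1ccc(Br)cc1)c1ccc([N+](=O)[O-])cc1` has one change (nitro in place of cyano on an aromatic carbon), with nitro in place of cyano on an aromatic carbon. Within the data shown here, no measured step makes this swap. Putting 4-cyanophenyl in place of 2,3,4,5,6-pentafluorophenyl gave no change at the digits printed from compound 1 to compound 3 (within the scatter) and only carboxy stood apart, as cyano in place of carboxy gave a modest 5.0-fold lower number from compound 2 to compound 3 (0.70 log units; beyond the scatter) on this scale. Neither step involves nitro, so no move beyond the scatter is expected in this assay and the expected result is no change at the digits printed from compound 3 to compound 4 (within the scatter) (an estimate). For compound 4 the estimated value is 10000 nM (range 4000 nM to 25000 nM).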

Compound 4, concentration for 50% growth inhibition: 10000 nM
For compound 4 middle estimate and measured number coincide at the digits printed, within the range that was stated.
By their numbers in this assay, from the lowest: compounds 1, 3 and 4 (each within the scatter of the next); then compound 2.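

In this assay, nitro on the aromatic carbon para to a large group matches cyano, with no change at the digits printed from compound 3 to compound 4 (within the scatter) at this position, and 4-nitrophenyl in place of 2,3,4,5,6-pentafluorophenyl gives no change at the digits printed from compound 1 to compound 4 (within the scatter) on the shared core. Carboxy now stands apart from a second group here, with a 5.0-fold lower number from compound 2 to compound 4 (0.70 log units; beyond the scatter) for the swap to nitro. Nothing measured here gives a reason for these results. Going by these compounds, how an amine or a methoxy group on this aromatic carbon would read stays open, as does whether any group here can give stronger inhibition of growth than nitro or cyano.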